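This account rests on a few compounds, and the source may have more. Where it says the series, first, only, none or still open, it means among the compounds named here.

Working notes on the series. Compound 3 `COc1nc(N)nc2c1c(-c1cccs1)cn2[C@@H]1O[C@H](CO)[C@@H](O)[C@H]1O` stands at the weak end of what has been measured: in a functional assay on HCT-116 cells (Homo sapiens), read by MTT assay, with a stated time of 72 h (on this read-out lower numbers stand for stronger inhibition and higher numbers for weaker inhibition), compound 3 gives only a limit of the assay, > 20000 nM, and not a number. Compound 2 `COc1nc(N)nc2c1c(-c1ccccc1)cn2[C@@H]1O[C@H](CO)[C@@H](O)[C@H]1O` likewise gives only a limit, > 20000 nM. Compound 1 `COc1ncnc2c1c(-c1ccoc1)cn2[C@@H]1O[C@H](CO)[C@@H](O)[C@H]1O`, which carries furan-3-yl but no amino group on the shared core, gives 130 nM. Compound 4 `COc1nc(N)nc2c1c(-c1ccoc1)cn2[C@@H]1O[C@H](CO)[C@@H](O)[C@H]1O` is not yet measured; it differs from compound 3 in one place: furan-3-yl in place of thiophen-2-yl on an aromatic carbon. Among the measured compounds shown here, the only measured step that bears on a change of the five-membered aromatic ring is a step that the two limits leave unreadable from compound 2 to compound 3, and its size cannot be read because of the limit of > 20000 nM in this assay, at which 2 of the 3 values shown sit. For the measured compounds named here, compound 1 shows that furan-3-yl on a core without the amino group sits well inside the measurable range, while both amino-bearing compounds measured so far sit at the limit. The step of an at least 1.3-fold lower number from compound 3 to compound 4 (0.12 log units; that floor lies within the scatter) is therefore expected to be small or not readable at all. For compound 4 a value of about 15000 nM is estimated, with a likely range from 2000 nM to 60000 nM.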

Compound 4, half-maximal inhibitory concentration: > 20000 nM
Compound 4 was reported as a limit; the forecaster's own chance of this, stated with the estimate: 60%; at least 1.3-fold (0.12 log units) between middle value and limit.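

Compound 4 gives only a limit of the assay and not a number. With furan-3-yl held fixed, amino in place of hydrogen on an aromatic carbon now forms a matched comparison in this assay, and it gives an at least 150-fold higher number from compound 1 to compound 4 (2.18 log units; beyond the scatter), so the amino group, not the change of aromatic ring, separates the two compounds in this pair. The steps among compound 2, compound 3 and compound 4 cannot be read, so phenyl, thiophen-2-yl and furan-3-yl cannot be ordered on the amino-bearing core because of this: the limit of > 20000 nM in this assay, at which 3 of the 4 values shown sit.

Going by these compounds, it remains open whether phenyl or thiophen-2-yl would stay within the measurable range on the core without the amino group, as furan-3-yl does in compound 1. On these data alone, it also remains open whether a methylamino group or a fluorine atom in place of the amino group would give a readable value.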